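The source may report more compounds than this note shows. Statements on the series, on what has been measured and on what is new or still open speak of the compounds shown alone.

Compound 1, `COC(=O)c1cccc(CN(CCCCC(N)=O)C[C@H]2O[C@@H](n3cnc4c(N)ncnc43)[C@H](O)[C@@H]2O)c1`: > 250000 nM
Compound 2, `COC(=O)c1cccc(CN(CCCC(=O)O)C[C@H]2O[C@@H](n3cnc4c(N)ncnc43)[C@H](O)[C@@H]2O)c1`: > 250000 nM

In an assay on cells for inhibition of Nicotinamide N-methyltransferase (Homo sapiens), with stated times of 10 min and 30 min (a lower number here means a stronger inhibitor, a higher number a weaker inhibitor), compound 1 gives only a limit of the assay, > 250000 nM. In this assay compound 2 also gives only a limit, > 250000 nM, so compound 2 stands at the edge of what the assay can report. The step from compound 1 to compound 2, a step that the two limits leave unreadable from compound 1 to compound 2, cannot be read because both values sit at the limit of > 250000 nM in this assay, at which 2 of the 2 values shown sit.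

Compound 3, `COC(=O)c1cccc(CN(CCCCC(=O)O)C[C@H]2O[C@@H](n3cnc4c(N)ncnc43)[C@H](O)[C@@H]2O)c1`, differs from compound 2 by carboxymethyl in place of carboxy on a saturated chain carbon, three bonds along the chain from an amine nitrogen. Only the unreadable step bears on this change, and the account therefore expects compound 3 to show a step that the limit leaves unreadable from compound 2 to compound 3, that is no step beyond the scatter. Compound 3 is estimated at 300000 nM, with a range from 100000 nM to 1000000 nM.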

Compound 3, half-maximal inhibitory concentration: > 250000 nM
Compound 3: no number, only a limit; the forecaster's own chance of this, stated with the estimate: 85%; the middle value does not contradict the limit.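

Compound 3 gives only a limit, > 250000 nM, in this assay, and no step among compound 1, compound 2 and compound 3 can be read: the limit of > 250000 nM in this assay, at which 3 of the 3 values shown sit.

The compounds shown leave open whether changing the chain length or its end group alters inhibition at all.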